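This account rests on a few compounds, and the source may have more. Where it says the series, first, only, none or still open, it means among the compounds named here.

Measured so far in a functional assay on NCI-H23 cells (Homo sapiens) for inhibition, read by sulforhodamine B assay, with a stated time of 48 h; on this read-out lower numbers stand for stronger inhibition of growth and higher numbers for weaker inhibition of growth:
compound 1 `CN1CCN(CCCOc2cccc3nc(Nc4ccc(Cl)c(C(F)(F)F)c4)ccc23)CC1` gives 1780 nM
compound 2 `CN1CCN(CCCOc2cccc3nc(Nc4ccc(F)c(F)c4)ccc23)CC1` gives 4670 nM

Both compounds share one core and differ only in the aromatic ring sitting on the nitrogen on the aromatic ring. Among these two numbers compound 2 stands highest, meaning weaker inhibition of growth, with compound 1 as its only neighbour: a 2.6-fold higher number from compound 1 to compound 2 (0.42 log units; beyond the scatter).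

Compound 3 `CN1CCN(CCCOc2cccc3nc(Nc4cccc(Cl)c4)ccc23)CC1` is the next variation, with 3-chlorophenyl in place of 3,4-difluorophenyl on a nitrogen on an aromatic ring. Among the compounds with values here, the one measured step that bears on this change is a 2.6-fold higher number from compound 1 to compound 2 (0.42 log units; beyond the scatter), in which 4-chloro-3-(trifluoromethyl)phenyl gave a lower number than 3,4-difluorophenyl. The 3-chlorophenyl ring of compound 3 carries a chlorine, as the ring of compound 1 does, so a modest step back towards a lower number is expected, estimated as a 1.7-fold lower number from compound 2 to compound 3 (0.22 log units; within the scatter). Compound 3 is therefore expected to give about 2800 nM in this assay, within a range from 1100 nM to 7000 nM.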

Compound 3, concentration for 50% growth inhibition: 2270 nM
Compound 3: middle estimate off by 1.2-fold (0.09 log units), on the high side; the range from low to high includes it.
By their numbers in this assay, from the lowest: compounds 1 and 3 (each within the scatter of the next); then compound 2.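

In this assay, the change on the nitrogen from 3,4-difluorophenyl to 3-chlorophenyl gives a 2.1-fold lower number from compound 2 to compound 3 (0.31 log units; beyond the scatter), so this position responds to a swap between two small halogen-bearing phenyl rings, and not only to the heavier substitution of compound 1. The other comparison gives a 1.3-fold higher number from compound 1 to compound 3 (0.11 log units; within the scatter), so 3-chlorophenyl and 4-chloro-3-(trifluoromethyl)phenyl cannot be told apart in this growth read-out. Among these three compounds, both rings that carry a chlorine therefore sit on the lower side of the 3,4-difluorophenyl ring of compound 2.

From the compounds shown here alone, whether this position tolerates anything other than a halogen-bearing phenyl ring stays open, and a ring carrying a methoxy group or an amine, or a pyridine ring, would test it. Nothing measured here accounts for these differences among the rings.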